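The source may report more compounds than this note shows. Statements on the series, on what has been measured and on what is new or still open speak of the compounds shown alone.

Working notes on the series, with all numbers from a functional assay on HeLa cells (Homo sapiens) for antiproliferative activity, read by MTT assay, with a stated time of 48 h; a higher number here means a weaker inhibitor, a lower number a stronger inhibitor. Compound 1 (`COc1ccc(C(=O)c2ccc(OC)c3c2C=CC(C)(C)O3)c(NC(=O)CBr)c1`) gives 3680 nM, compound 2 (`COc1ccc(C(=O)c2ccc(OC)c3c2OC(C)(C)C=C3)c(NC(=O)CO)c1`) gives 100 nM, and compound 3 (`COc1ccc(C(=O)c2ccc3c(c2)C=CC(C)(C)O3)c(NC(=O)CO)c1`) gives 240 nM. Compound 3 is therefore the middle of the three numbers, with compound 2 lower and compound 1 higher, both gaps beyond the scatter.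

Compound 4 (`COc1ccc(C(=O)c2ccc3c(c2)C=CC(C)(C)O3)c(NC(=O)CN(C)C)c1`) has dimethylamino in place of hydroxy on a saturated chain carbon bound to a carbonyl carbon.

Within the data shown here, no measured pair differs in one place only, so the size of this step in this assay cannot be read directly from the series. A modest move towards a higher number is expected, and a result within the scatter would not be surprising. The anchor is compound 3 at 240 nM. Compound 1 at 3680 nM carries a different group on the same chain, but it also differs elsewhere and offers only weak guidance. The expected step is a 1.7-fold higher number from compound 3 to compound 4 (0.22 log units; within the scatter). For compound 4 the estimated value is 400 nM, with an expected range of 130 nM to 1300 nM.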

Compound 4, half-maximal inhibitory concentration: 1260 nM
The estimate for compound 4 lay 3.2-fold (0.50 log units) below the measured number, and the stated range covers the measured number.
By their numbers in this assay, from the lowest: compound 2; then compound 3; then compound 4; then compound 1.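

In this assay, among these compounds, dimethylamino in place of hydroxy on a saturated chain carbon bound to a carbonyl carbon gives a 5.3-fold higher number from compound 3 to compound 4 (0.72 log units; beyond the scatter), the first change that can be read in one place only. This position therefore responds to the group it carries, which compound 1, compound 2 and compound 3 could not show, as each differs from the others in more than one place. No measurement at hand accounts for the size of this step.

The change alters the heavy atom count and removes the hydrogen-bond donor together, and the compounds shown do not separate the two. As far as these compounds go, it also remains open how an unsubstituted amine or a methoxy group would read on the same chain carbon, and whether the step carries over to the core of compound 2.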